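This account rests on a few compounds, and the source may have more. Where it says the series, first, only, none or still open, it means among the compounds named here.

In an ADME assay on L6 cells (Rattus norvegicus) for cytotoxicity, with a stated time of 72 h (a higher number here means a weaker inhibitor, a lower number a stronger inhibitor), compound 1 (`CN(C)C12CC(OC(=O)CN3CCCC3)C(C(c3ccccc3)C1)C(c1ccccc1)C2`) gives 32700 nM. That places it level, within the scatter, with compound 2 (`CN(C)C12CC(OC(=O)CN3CCCCC3)C(C(c3ccccc3)C1)C(c1ccccc1)C2`) at 29300 nM, and on the lower side of compound 3 (`CN(C)C12CC(O)C(C(c3ccccc3)C1)C(c1ccccc1)C2`) at 133000 nM. Compound 4 (`O=C(CN1CCCC1)OC1CC2(N3CCCCC3)CC(c3ccccc3)C1C(c1ccccc1)C2`) departs from compound 1 at a different place: piperidin-1-yl in place of dimethylamino on a saturated ring carbon. For the measured compounds named here, no measured step touches this group, so the evidence is indirect. The nearest parallel is the same kind of ring swap on the ester side chain, a 1.1-fold lower number from compound 1 to compound 2 (0.05 log units; within the scatter), which made no real difference. The larger steps, a 4.1-fold higher number from compound 1 to compound 3 (0.61 log units; beyond the scatter) and a 4.5-fold higher number from compound 2 to compound 3 (0.66 log units; beyond the scatter), both come from losing the whole ester group, which compound 4 keeps. Only a small shift is therefore expected in this assay. The estimated change is a 1.5-fold lower number from compound 1 to compound 4 (0.17 log units; within the scatter), a slight lean to a lower number that stays inside the scatter. For compound 4 the expected value is 22000 nM, with an estimated range from 8000 nM to 55000 nM.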

Compound 4, half-maximal inhibitory concentration: 16400 nM
Beside the measured number, compound 4's estimate is 1.3-fold (0.13 log units) above it; the measured number falls inside the stated range.
By their numbers in this assay, from the lowest: compounds 4, 2 and 1 (each within the scatter of the next); then compound 3.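

At this position, on a saturated ring carbon of the core, this assay gives the first direct reading: piperidin-1-yl in place of dimethylamino gives a 2.0-fold lower number from compound 1 to compound 4 (0.30 log units; within the scatter) and so brings a ring onto this carbon without a change beyond the scatter. Together with the ring swap on the ester side chain, this means that neither of the two amine changes shown moves the number beyond the scatter, while the steps beyond it shown so far are those that remove the whole ester group. No measured evidence here accounts for the result.

The compounds shown leave open whether a primary amine or a morpholin-4-yl group on this ring carbon would also stay level with compound 1. They also leave open whether piperidin-1-yl here would read the same in the free alcohol, compound 3, which lacks the ester.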